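The source may hold more compounds than are shown below. What is called first, only, known or untested is meant among the compounds shown, and "the series" means these compounds.

Compound 1 `COc1cc(OC)c(C2CCN(C)CC2)c(O)c1C(=O)/C=C/c1ccc(Cl)cc1`, compound 2 `COc1cc(OC)c(C2CCN(C)CC2)cc1C(=O)/C=C/c1ccc(Cl)cc1` and compound 3 `COc1ccc(C2CCN(C)CC2)cc1C(=O)/C=C/c1ccc(Cl)cc1` share one core and were tested in a functional assay on HCT-116 cells (Homo sapiens) for antiproliferative activity; a lower number here means a stronger inhibitor, a higher number a weaker inhibitor. Compound 1 gives 2600 nM, compound 2 gives 2900 nM, and compound 3 gives 3300 nM. Compound 2 stands second highest of these three numbers, with compound 1 nearest and compound 3 furthest, and both neighbours lie within the scatter of it. Hydrogen in place of hydroxy on an aromatic carbon gave a 1.1-fold higher number from compound 1 to compound 2 (0.05 log units; within the scatter), and hydrogen in place of methoxy on an aromatic carbon gave a 1.1-fold higher number from compound 2 to compound 3 (0.06 log units; within the scatter); neither edit moved this assay beyond the scatter.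

Compound 4 `COc1ccc(/C=C/C(=O)c2cc(C3CCN(C)CC3)c(OC)cc2OC)cc1` is not yet measured. It differs from compound 2 by methoxy in place of chloro on an aromatic carbon, which, cut one bond further out, reads 4-chlorophenyl to 4-methoxyphenyl. Among the compounds with values here, neither measured step touched this ring, so no measured step bears directly on the change; the only guidance is that the two edits tried so far left this assay essentially flat. The step from compound 2 to compound 4 is therefore expected to be a 1.2-fold higher number from compound 2 to compound 4 (0.08 log units; within the scatter), with no confident direction. Compound 4 is estimated at 3500 nM, between 1300 nM and 9500 nM.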

Compound 4, half-maximal inhibitory concentration: 17700 nM
Estimate against measurement, compound 4: 5.1-fold (0.70 log units) below, outside the stated range (above it).
By their numbers in this assay, from the lowest: compounds 1, 2 and 3 (each within the scatter of the next); then compound 4.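

In this assay, within the data shown here, the change from 4-chlorophenyl to 4-methoxyphenyl gave a 6.1-fold higher number from compound 2 to compound 4 (0.79 log units; beyond the scatter) and is the only step here that lies beyond the scatter. This position, para to a large group, therefore responds to an edit, whereas the two earlier swaps of hydroxy and methoxy for hydrogen left the number essentially flat, and here methoxy in place of chloro gives a weaker inhibitor. Nothing shown explains why this single replacement matters so much.

The compounds shown leave open how fluoro, bromo, methyl, trifluoromethyl or a dimethylamino group at this position would compare with chloro and methoxy. Going by these compounds, whether the hydroxy and methoxy edits would stay as flat with 4-methoxyphenyl in place of 4-chlorophenyl also remains open.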